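Benzyl in Place of Carbamoylmethyl on a Guanine-Like Core

The source may hold more compounds than are shown below. What is called first, only, known or untested is meant among the compounds shown, and "the series" means these compounds.

Of the compounds shown here, two sharing one core have been tested in a functional assay on the whole organism (B cells) with Mus musculus as the target; on this read-out higher numbers stand for larger maximal responses and lower numbers for smaller maximal responses. Compound 1, with structure `C=CCn1c(=O)n(CCCCO)c2nc(N)nc(O)c21`, gives 12% in this assay. Compound 2, with structure `NC(=O)Cn1c(=O)n(C2OC(CO)[C@@H](O)[C@H]2O)c2nc(N)nc(O)c21`, gives 32%. Of these two numbers, compound 2 stands highest, and its gap to compound 1 is beyond the usual scatter of the assay.

The next compound, compound 3 with structure `Nc1nc(O)c2c(n1)n(C1OC(CO)[C@@H](O)[C@H]1O)c(=O)n2Cc1ccccc1`, is not yet measured. It differs from compound 2 in one place: phenyl in place of carbamoyl on a saturated chain carbon bound to an aromatic nitrogen. Among the measured compounds shown here, no measured pair shows this exact change, so its effect cannot be read from the numbers at hand.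

For the measured compounds named here, with only two measured compounds and no comparable step, the expected change from compound 2 to compound 3, a number 7 percentage points lower from compound 2 to compound 3 (within the scatter), is estimated as small and uncertain in direction. For compound 3 the estimated maximal response is 25%, with a range from 5% to 60%.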

Compound 3, largest response reached (reported as maximal response), in percent of the reference or control that the assay uses: 110%
Estimate against measurement, compound 3: 85 percentage points below; the measured number lies above the stated range.
By their numbers in this assay, from the lowest: compound 1; then compound 2; then compound 3.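

Swapping carbamoyl for phenyl on a saturated chain carbon bound to an aromatic nitrogen, which turns carbamoylmethyl into benzyl, gives a number 78 percentage points higher from compound 2 to compound 3 (beyond the scatter) in this assay, so what sits at this position has a large effect on the response. Compound 1 and compound 2 differ in more than one place, so their gap could not show this for the position alone. No measurement at hand accounts for the size of this step, and its cause remains unknown.

On these data alone, it remains open whether the response depends on the aromatic ring itself, which a cyclohexylmethyl group in place of benzyl would test. A phenethyl group, with its longer chain, or a methoxy group on the phenyl ring could show how much change this position tolerates.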